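Dichlorophenyl replaces methoxyphenyl on the unsaturated chain

The source may hold more compounds than are shown below. What is called first, only, known or untested is meant among the compounds shown, and "the series" means these compounds.

Two compounds of the series carry a measured value in an in vitro assay on cells for inhibition of Amine oxidase [flavin-containing] B (Homo sapiens), read by fluorescence and Amplex Red, with stated times of 30 min and 45 min; a higher number here means a weaker inhibitor, a lower number a stronger inhibitor. Compound 1 `COc1cccc(CCC(=O)Nc2nc3ccccc3c(=O)s2)c1` gives 95.3 nM in this assay. Compound 2 `COc1cccc(/C=C/CC(=O)Nc2nc3ccccc3c(=O)s2)c1` gives 238 nM in this assay. Going by the values given here, compound 2 thus stands at the higher of the two numbers, and compound 1 sits at a lower number by a gap that is beyond the usual scatter; the two differ in the saturation of the chain, and no single-change step between them is recorded.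

Compound 3 `O=C(C/C=C/c1ccc(Cl)c(Cl)c1)Nc1nc2ccccc2c(=O)s1` is the next compound to be measured. It differs from compound 2 in one place: 3,4-dichlorophenyl in place of 3-methoxyphenyl on a double-bonded chain carbon bound to a double-bonded chain carbon. Among the compounds with values here, no measured pair shows this exchange, so the size and direction of the step cannot be read from the data. The step from compound 2 to compound 3 is therefore expected to be small, estimated as a 1.6-fold lower number from compound 2 to compound 3 (0.20 log units; within the scatter), with a wide band around it. For compound 3 in this assay the expected value is 150 nM, with a range from 40 nM to 600 nM.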

Compound 3, half-maximal inhibitory concentration: > 10000 nM
Compound 3 was reported as a limit; the forecaster's own chance of this, stated with the estimate: 5%; middle value at least 66-fold (1.82 log units) away from the limit.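

In this assay the exchange of 3-methoxyphenyl for 3,4-dichlorophenyl, on a double-bonded chain carbon bound to a double-bonded chain carbon, gives an at least 42-fold higher number from compound 2 to compound 3 (1.62 log units; beyond the scatter) and so is a large step. The reading for compound 3 is a limit of the assay and not a number: the limit of > 10000 nM in this assay, at which 1 of the 3 values shown sits. The earlier compounds shown here showed only a change in the chain, with compound 1 at 95.3 nM and compound 2 at 238 nM in this assay, whereas this aryl position now proves far from indifferent, and a single exchange there moves the number much further than that chain change did.

The compounds shown do not separate the departure of the methoxy group from the arrival of the two chlorine atoms, and an unsubstituted phenyl or a monochlorophenyl at this place would be needed to tell these apart. Whether 3,4-dichlorophenyl on the saturated chain of compound 1 gives the same result also stays open, as does the reason for the step.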